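Imidazopyrazine-benzimidazole pair: a naphthyl swap

The source may report more compounds than this note shows. Statements on the series, on what has been measured and on what is new or still open speak of the compounds shown alone.

Measured so far:
compound 1 `COc1ccc(-c2cn3ccnc3c(-c3ccc4ncn(C5CCCCC5)c4c3)n2)cc1` — 69.6%
compound 2 `CCc1ccc(-c2cn3ccnc3c(-c3ccc4ncn(Cc5ccccc5)c4c3)n2)cc1` — 50.2%

Two compounds sharing the core have been run in a functional assay on LOX IMVI cells (Homo sapiens) for inhibition, read by sulforhodamine B assay, with a stated time of 48 h, tested at 10 uM; a higher number here means more inhibition at the concentration tested (going by the name of the read-out), a lower number less inhibition. Compound 1 gives 69.6%, while compound 2 gives 50.2%. Compound 2 stands lowest of the two numbers; its nearest neighbour, compound 1, lies higher by a margin that is beyond the scatter. Among the measured compounds shown here, the two compounds differ in more than one place, so no single step is drawn between them, and only what the two values show can be said.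

The next compound, compound 3 `c1ccc(Cn2cnc3ccc(-c4nc(-c5cccc6ccccc56)cn5ccnc45)cc32)cc1`, keeps the benzyl substituent of compound 2 and changes the other aryl group: naphthalen-1-yl in place of 4-ethylphenyl on an aromatic carbon. The 4-ethylphenyl leaves and naphthalen-1-yl enters on an aromatic carbon of a six-membered aromatic ring with 2 nitrogen, part of a fused system of two rings.

For the measured compounds named here, no comparable step has been measured, so the size of this change is open. The step from compound 2 is expected to be small, most likely none beyond the scatter, as a number 2.2 percentage points lower from compound 2 to compound 3 (within the scatter). Compound 3 is thus estimated at 48%, with a range from 22% to 74%.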

Compound 3, a percentage reported as inhibition, at one concentration (the size of the read-out at that concentration, not a potency): 16.5%
The estimate for compound 3 lay 31.5 percentage points above the measured number, and the stated range ends above it.
By their numbers in this assay, from the lowest: compound 3; then compound 2; then compound 1.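

In this assay, the aromatic carbon of the six-membered aromatic ring with 2 nitrogen proves sensitive to the aryl group it carries: with the benzyl substituent held constant, naphthalen-1-yl in place of 4-ethylphenyl gives a number 33.7 percentage points lower from compound 2 to compound 3 (beyond the scatter). Among the compounds shown here, this is the first single-place comparison, and it shows that the position does not accept every carbon-only aryl group equally, since a change from one six-membered aromatic ring of 8 heavy atoms to two such rings with 10 heavy atoms is enough to produce a large step. Nothing available explains the size of this step.

The two compounds cannot separate the effect of the second aromatic ring from that of removing the ethyl group, and a plain phenyl, naphthalen-2-yl, or a phenyl carrying an amine or a carboxylic acid in place of the ethyl would help to do so. Also open, going by these compounds, is whether the step holds with other substituents in place of benzyl, such as the cyclohexyl of compound 1.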